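The compounds below may be only part of what the source reports. "The series", "measured", "known", "first", "only" and "open" are said of these compounds alone.

Compound 1, `COc1ccc(-c2cs/c(=N/NC(=O)CSc3nnc(C)s3)n2-c2ccccc2)cc1`, gives 57.9% in a functional assay on C6 cells (Rattus norvegicus) for cytotoxicity, read by MTT assay, with a stated time of 24 h, tested at 6 ug/mL; a lower number here means a stronger effect, a higher number a weaker effect of the compound at the concentration tested.
Compound 2, `O=C(CSc1ncccn1)N/N=c1/scc(-c2ccc(Cl)cc2)n1-c1ccccc1`, gives 95.9%.
Compound 3, `Cc1ccc(-c2cs/c(=N/NC(=O)CSc3ncccn3)n2-c2ccccc2)cc1`, gives 93.2%.

Compound 3 holds the second highest number of the three; compound 2 is nearest, and the step of a number 2.7 percentage points lower from compound 2 to compound 3 (within the scatter) lies within the scatter, while compound 1 stands far lower. Compound 4, `COc1ccc(-c2cs/c(=N/NC(=O)CSc3ncccn3)n2-c2ccccc2)cc1`, differs from compound 3 by methoxy in place of methyl on an aromatic carbon. Among the measured compounds shown here, no measured step covers this exchange. For the measured compounds named here, the only measured step, a number 2.7 percentage points lower from compound 2 to compound 3 (within the scatter), exchanged a group on the same aromatic carbon without moving beyond the scatter, which points to a small step here too; compound 1 carries a methoxy on a different core and gives a lower number, but stands in no single-change comparison to compound 3. Compound 4 is therefore expected at 86%, between 62% and 100%, an expected step of a number 7.2 percentage points lower from compound 3 to compound 4 (within the scatter).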

Compound 4, a percentage reported as activity, at one concentration (the size of the read-out at that concentration, not a potency): 89.6%
For compound 4 the middle estimate is 3.6 percentage points below the measured one, within the range that was stated.
By their numbers in this assay, from the lowest: compound 1; then compounds 4, 3 and 2 (each within the scatter of the next).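

In this assay, methoxy on this aromatic carbon behaves like the groups seen there before, with a number 3.6 percentage points lower from compound 3 to compound 4 (within the scatter) and a number 6.3 percentage points lower from compound 2 to compound 4 (within the scatter), so chloro, methyl and methoxy are not told apart. The group on the sulfur can now be read on its own, and the exchange of 5-methyl-1,3,4-thiadiazol-2-yl for pyrimidin-2-yl gives a number 31.7 percentage points higher from compound 1 to compound 4 (beyond the scatter), so the low number of the earlier methoxy compound goes with that group and not with methoxy. Nothing available explains either result. Open, as far as these compounds go, is whether an amine or a carboxylic acid on this aromatic carbon would move the number beyond the scatter, and how other rings on the sulfur would compare.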